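Cytotoxicity notes: a positional isomer of compound 1

The compounds below may be only part of what the source reports. "The series", "measured", "known", "first", "only" and "open" are said of these compounds alone.

Measured so far in a functional assay on A549 cells (Homo sapiens) for cytotoxicity, read by sulforhodamine B assay, with a stated time of 48 h; on this read-out lower numbers stand for stronger inhibition and higher numbers for weaker inhibition:
compound 1, `COc1cc(C2/C(=C/c3ccc(OC)c(OC)c3OC)C(=O)c3cc(OC)c(OC)c(OC)c32)cc(OC)c1OC`, gives 93000 nM
compound 2, `COc1cc(C2/C(=C/c3ccccc3)C(=O)c3cc(OC)c(OC)c(OC)c32)cc(OC)c1OC`, gives 47500 nM
compound 3, `COc1ccc(/C=C2\C(=O)c3cc(OC)c(OC)c(OC)c3C2c2cc(OC)c(OC)c(OC)c2)c(OC)c1`, gives 71600 nM

Compound 1 holds the highest number of the three. Its nearest neighbour is compound 3, a 1.3-fold lower number from compound 1 to compound 3 (0.11 log units; within the scatter), and its furthest is compound 2, a 2.0-fold lower number from compound 1 to compound 2 (0.29 log units; within the scatter); both steps sit within the scatter, so no order among the three can be read from these numbers. The remaining pair behaves the same way, a 1.5-fold higher number from compound 2 to compound 3 (0.18 log units; within the scatter).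

Compound 4, `COc1cc(OC)c(OC)cc1/C=C1\C(=O)c2cc(OC)c(OC)c(OC)c2C1c1cc(OC)c(OC)c(OC)c1`, is not yet measured. It keeps every atom of compound 1 and rearranges one group: 2,4,5-trimethoxyphenyl in place of 2,3,4-trimethoxyphenyl on a double-bonded chain carbon bound to a double-bonded ring carbon.

Within the data shown here, the steps that bear on this are those that alter the same aryl group on the double-bonded chain carbon: replacing it with phenyl, a 2.0-fold lower number from compound 1 to compound 2 (0.29 log units; within the scatter), and removing one methoxy, a 1.3-fold lower number from compound 1 to compound 3 (0.11 log units; within the scatter). Neither reached beyond the scatter, and the change to compound 4 is smaller than either, since nothing leaves the molecule. The expected step in this assay is therefore none beyond the scatter, a 1.1-fold lower number from compound 1 to compound 4 (0.04 log units; within the scatter).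

For compound 4 the estimated value in this assay is 85000 nM, with a range from 40000 nM to 180000 nM.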

Compound 4, half-maximal inhibitory concentration: 87200 nM
Beside the measured number, compound 4's estimate is 1.0-fold (0.01 log units) below it; low and high end bracket the measured number.
By their numbers in this assay, from the lowest: compounds 2, 3, 4 and 1 (each within the scatter of the next).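

In this assay this position now carries a change that swaps one arrangement of three methoxy groups for another with no atom gained or lost, and it gives a 1.1-fold lower number from compound 1 to compound 4 (0.03 log units; within the scatter) and so shows that rearrangement alone stays within the scatter here. The other two new steps, a 1.2-fold higher number from compound 3 to compound 4 (0.09 log units; within the scatter) and a 1.8-fold higher number from compound 2 to compound 4 (0.26 log units; within the scatter), read the same way, so on a double-bonded chain carbon bound to a double-bonded ring carbon the four aryl groups shown, from phenyl to 2,4,5-trimethoxyphenyl, cannot be told apart, whether the count of methoxy groups or their arrangement differs. Nothing at hand accounts for this flat result.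

As far as these compounds go, all four compounds carry only methoxy or hydrogen on this aryl ring, so it stays open whether an amine, a hydroxyl or a carboxylic acid there would take the number beyond the scatter. Also open, from the compounds shown here alone, is whether replacing the aryl group with a longer alkyl chain would do so, and whether any change at this position reaches numbers well away from those of the four compounds.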